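The source may hold more compounds than are shown below. What is called first, only, known or untested is meant among the compounds shown, and "the series" means these compounds.

The measured compounds are compound 1 `CN(C)CCCN(/N=N/c1ccccc1)c1ccccc1`, compound 2 `c1ccc(/N=N/N2CCN(c3ccccc3)CC2)cc1` and compound 3 `CCOC(=O)N1CCN(/N=N/c2ccccc2)CC1`. In an ADME assay on MDBK cells (Bos taurus) for cytotoxicity, read by MTT assay, with a stated time of 96 h (a lower number here means that less compound is tolerated, a higher number that more compound is tolerated), compound 1 gives 95000 nM. Compound 2 gives only a limit, > 100000 nM. Compound 3 likewise gives only a limit, > 100000 nM.

Compound 3 therefore stands at the ceiling of this assay, sharing that position with one further value, as the limit of > 100000 nM in this assay, at which 2 of the 3 values shown sit, records. Within the data shown here, the only step between measured compounds, a step that the two limits leave unreadable from compound 2 to compound 3, cannot be read. Compound 4 `c1ccc(/N=N/N2CCN(c3ncccn3)CC2)cc1` differs from compound 3 by pyrimidin-2-yl in place of ethoxycarbonyl on an amine nitrogen in a ring. Among the measured compounds shown here, no measured step covers this change, so no shift beyond the scatter is expected. Compound 4 is expected to stay at the ceiling, a step of a number no higher from compound 3 to compound 4 (the limit leaves the size open). Compound 4 is estimated at 100000 nM, between 50000 nM and 200000 nM.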

Compound 4, half-maximal cytotoxic concentration: > 100000 nM
Compound 4 gave a limit, no number (the forecaster's own chance of this, stated with the estimate: 70%); the middle value lies on the limit itself.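

Compound 4, like compound 2 and compound 3, gives only a limit in this assay, so no step among these three compounds can be read: the limit of > 100000 nM in this assay, at which 3 of the 4 values shown sit.

From the compounds shown here alone, whether pyrimidin-2-yl, ethoxycarbonyl and phenyl on an amine nitrogen in a ring differ at all in this read-out stays open.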